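The source may report more compounds than this note shows. Statements on the series, on what has been measured and on what is new or still open speak of the compounds shown alone.

Measured compounds, growth inhibition in a functional assay on SK-MEL-5 cells (Homo sapiens) for inhibition, read by sulforhodamine B assay, with a stated time of 48 h; on this read-out lower numbers stand for stronger inhibition of growth and higher numbers for weaker inhibition of growth:

compound 1 `COc1cc(-c2nn(-c3cccc(NC(=O)Nc4ccc(Cl)c(Cl)c4)c3)cc2-c2ccncc2)ccc1Cl`: 741 nM
compound 2 `O=C(Nc1cccc(-n2cc(-c3ccncc3)c(-c3ccc(Cl)c(O)c3)n2)c1)Nc1ccc(Cl)c(Cl)c1`: 570 nM
compound 3 `O=C(Nc1cccc(-n2cc(-c3ccncc3)c(-c3ccc(Cl)c(O)c3)n2)c1)Nc1cc(C(F)(F)F)cc(C(F)(F)F)c1`: 600 nM

Compound 1 gives the highest of the three numbers, yet its gaps to compound 2 and compound 3 both lie within the scatter, so the three measured compounds stand together. Within the data shown here, the one single-point step measured so far is a 1.3-fold lower number from compound 1 to compound 2 (0.11 log units; within the scatter), which is within the scatter. Among the measured compounds shown here, compound 2 and compound 3 differ in the aryl group on the far side of the urea; no step is computed for that pair, and their two values show no separation beyond the scatter.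

Compound 4 `COc1cc(-c2nn(-c3cccc(NC(=O)c4ccccc4)c3)cc2-c2ccncc2)ccc1Cl` is not yet measured. It differs from compound 1 by phenyl in place of (3,4-dichlorophenyl)amino on a carbonyl carbon, that is, the urea of compound 1 becomes a benzamide. For the measured compounds named here, none of the measured steps touches the carbonyl carbon or removes the second amide-type nitrogen, so nothing measured here bears directly on this change. Compound 2 and compound 3 together suggest that the distal aryl ring tolerates exchange, but removing the amino link is a different change. Given that absence of guidance and the size of the change, compound 4 is expected to give a weaker number, with wide uncertainty: a 2.7-fold higher number from compound 1 to compound 4 (0.43 log units; beyond the scatter), estimated at 2000 nM with a range from 600 nM to 7000 nM.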

Compound 4, concentration for 50% growth inhibition: 319 nM
Compound 4: middle estimate off by 6.3-fold (0.80 log units), on the high side, outside the stated range (below it).
By their numbers in this assay, from the lowest: compounds 4, 2, 3 and 1 (each within the scatter of the next, the first and the last beyond it).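

In this assay the position on the carbonyl carbon takes phenyl in place of (3,4-dichlorophenyl)amino with a 2.3-fold lower number from compound 1 to compound 4 (0.37 log units; beyond the scatter), a modest step beyond the scatter. The earlier compounds shown here kept the urea and varied only the aryl group on its far side, whereas this step removes the urea itself and shows that, on the core of compound 1, growth inhibition persists without the amino link, its hydrogen-bond donor or the two chlorines. No measured evidence accounts for the lower number.

This single step takes out the amino link and both chlorines together, and the compounds shown do not divide the effect between them, so a benzoyl group carrying the same chlorines remains the open comparison. Also open, going by these compounds, are whether the phenyl of the benzamide accepts further groups, such as a carboxylic acid or a dimethylamino group, and whether hydrogen in place of methyl on the oxygen on the aromatic ring changes the number when the benzamide is present.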